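The compounds below may be only part of what the source reports. "The series", "measured", "known", "first", "only" and "open" are said of these compounds alone.

The numbers for this series in a functional assay on A549 cells (Homo sapiens) for antiproliferative activity, read by MTT assay, with a stated time of 72 h (a higher number here means a weaker inhibitor, a lower number a stronger inhibitor), are few. Compound 1 `COc1ncc(-c2ccc3c(c2)N(c2ccc(F)cc2)C(=O)CO3)cc1NS(=O)(=O)c1ccc(F)cc1` gives 6500 nM, and compound 2 `COc1ncc(-c2ccc3c(c2)N(c2ccccc2)C(=O)CO3)cc1NS(=O)(=O)c1ccc(F)cc1` gives 3490 nM. Compound 3 `Cc1ccc(N2C(=O)COc3ccc(-c4cnc5ccccc5c4)cc32)cc1` is reported as > 40000 nM, which is a limit of this assay and not a number. This entry is the limit of > 40000 nM in this assay, at which 1 of the 3 values shown sits, so compound 3 has no exact position in the series.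

Compound 4 `O=C1COc2ccc(-c3cnc4ccccc4c3)cc2N1` keeps the core of compound 3 and differs at one place: hydrogen in place of 4-methylphenyl on an amide-type nitrogen in a ring. Hydrogen replaces 4-methylphenyl on an amide-type nitrogen in a ring, so the whole aromatic substituent is gone.

Among the compounds with values here, only one measured step is available, a 1.9-fold lower number from compound 1 to compound 2 (0.27 log units; within the scatter). It lies within the scatter and concerns a much smaller exchange, hydrogen in place of fluoro on an aromatic carbon, so it gives little guidance on removing an entire ring. Within the data shown here, no measured pair shows the loss of this group. With no support for a gain or a loss, no step beyond the scatter is expected, and compound 4 may also be reported only as a limit.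

The expected step is a number no higher from compound 3 to compound 4 (the limit leaves the size open). For compound 4 the estimated value is 40000 nM, with an expected range from 15000 nM to 80000 nM.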

Compound 4, half-maximal inhibitory concentration: > 40000 nM
Compound 4: only a limit was reported; the forecaster's own chance of this, stated with the estimate: 65%; the middle value lies on the limit itself.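

Compound 3 and compound 4 are both reported only as limits in this assay, so no step between them can be read: the limit of > 40000 nM in this assay, at which 2 of the 4 values shown sit.

The compounds shown leave open what hydrogen in place of 4-methylphenyl on the amide-type nitrogen does to the activity, as no pair with exact values shows this exchange.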